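The source may report more compounds than this note shows. Statements on the series, on what has been measured and on what is new or still open speak of the compounds shown alone.

Compound 2 `C/N=C(\S)NCCCCCCn1nc(-c2ccccc2)ccc1=O` stands lowest of the two numbers gathered so far in a functional assay on the whole organism with Rattus norvegicus as the target, at a dose of 100 mg/kg (a higher number here means more inhibition at the dose given (going by the name of the read-out), a lower number less inhibition), where compound 2 gives 22.2%. Going by the values given here, its nearest neighbour, compound 1 `N#CNC(=N)NCCCCn1nc(-c2ccccc2)ccc1=O`, gives 61.2%, and the one measured step, a number 39 percentage points lower from compound 1 to compound 2 (beyond the scatter), swapped the group on the chain while the chain itself also grew. Compound 3 `C/N=C(\S)NCCCn1nc(-c2ccccc2)ccc1=O` keeps the same kind of group but shortens the chain: a group of 5 heavy atoms (2 carbon, 2 nitrogen, 1 sulfur; no ring) in place of a group of 8 heavy atoms (5 carbon, 2 nitrogen, 1 sulfur; no ring), on a saturated chain carbon, three bonds along the chain from an aromatic nitrogen. Among the compounds with values here, no measured step isolates a chain shortening, so its direction is open. Compound 3 is expected near 30%, within 5% to 60%. That expectation means a step of a number 7.8 percentage points higher from compound 2 to compound 3 (within the scatter).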

Compound 3, a percentage reported as inhibition, in the whole organism at one dose (the size of the read-out at that dose, not a potency): 38.9%
The estimate for compound 3 lay 8.9 percentage points below the measured number; the measured number falls inside the stated range.
By their numbers in this assay, from the lowest: compound 2; then compound 3; then compound 1.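

With the end group kept and only the chain shortened in this assay, there is a number 16.7 percentage points higher from compound 2 to compound 3 (beyond the scatter), so chain length alone can move this read-out, something the earlier step could not separate from the change of group. There is also a number 22.3 percentage points lower from compound 1 to compound 3 (beyond the scatter), but that step changes both the group and the chain, so it gives neither change its own share. Nothing measured here explains why the numbers move this way. On these data alone, whether a two-carbon chain would continue the rise remains open, as does how a simple amine at the chain end would compare.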